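The source may hold more compounds than are shown below. What is called first, only, known or untested is meant among the compounds shown, and "the series" means these compounds.

Compound 1 `COC(=O)c1nc(C)n(-c2ccccc2)n1` and compound 2 `COC(=O)c1nc(C)n(-c2ccc(C(F)(F)F)cc2)n1` share one core and differ only by trifluoromethyl in place of hydrogen on an aromatic carbon. In a functional assay on Jurkat cells (Homo sapiens) for inhibition, read by MTT assay, with a stated time of 72 h (on this read-out lower numbers stand for stronger inhibition of growth and higher numbers for weaker inhibition of growth), compound 1 reaches only the limit of > 100000 nM. In this assay compound 2 gives 9100 nM, and the step of an at least 10-fold lower number from compound 1 to compound 2 (1.04 log units; beyond the scatter) is a large one. For the measured compounds named here, compound 2 thus holds the only number in this assay; the other entry is the limit of > 100000 nM in this assay, at which 1 of the 2 values shown sits.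

Compound 3 `COC(=O)c1nc(-c2ccsc2)n(-c2ccc(C(F)(F)F)cc2)n1` keeps the trifluoromethyl and changes a different place: thiophen-3-yl in place of methyl on an aromatic carbon. Going by the values given here, no measured step touches that carbon, so the single measured step, an at least 10-fold lower number from compound 1 to compound 2 (1.04 log units; beyond the scatter), gives no direct guide to the size or direction of the new one. Without a measured precedent, compound 3 is expected to show a step of a 3.0-fold lower number from compound 2 to compound 3 (0.48 log units; beyond the scatter), a modest gain. Compound 3 is therefore estimated at 3000 nM in this assay, within a range from 500 nM to 20000 nM.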

Compound 3, concentration for 50% growth inhibition: > 100000 nM
Compound 3: a limit, no number; the forecaster's own chance of this, stated with the estimate: 10%; middle value at least 33-fold (1.52 log units) away from the limit.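

In this assay, thiophen-3-yl in place of methyl on the aromatic carbon between two ring nitrogen atoms gives an at least 10-fold higher number from compound 2 to compound 3 (1.04 log units; beyond the scatter), a large step in the direction opposite to an at least 10-fold lower number from compound 1 to compound 2 (1.04 log units; beyond the scatter). Compound 3 gives > 100000 nM, which is a limit of the assay and not a number. This shows that the carbon bearing the methyl group also matters for the read-out, and that keeping the trifluoromethyl does not preserve a measurable value once thiophen-3-yl enters there: the limit of > 100000 nM in this assay, at which 2 of the 3 values shown sit.

The compounds shown leave open whether ethyl or a lone hydrogen on this carbon would match compound 2, and whether a ring such as phenyl or furan-3-yl would behave like thiophen-3-yl. Also open, going by these compounds, is what a carboxylic acid or an amide in place of the methoxycarbonyl group would do.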